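Shrinking the amine substituent on the thienopyridine urea series

The compounds below may be only part of what the source reports. "The series", "measured", "known", "first", "only" and "open" are said of these compounds alone.

In a functional assay (strain AB) with Danio rerio as the target, read by microscopy, with a stated time of 1 h (a higher number here means that more compound is needed for the effect, a lower number that less compound is needed), compound 1 `NC(=O)c1c(NC(=O)Nc2ccc(Cl)cc2)sc2c1CCN(CC1CCCCC1)C2` gives 1890 nM, the higher of the two numbers in hand. Compound 2 `COCCC[N+]1(C)CCc2c(sc(NC(=O)Nc3ccc(Cl)cc3)c2C(N)=O)C1` gives 480 nM in this assay, a lower number and a difference beyond the usual scatter. The next member is compound 3 `CCCN1CCc2c(sc(NC(=O)Nc3ccc(Cl)cc3)c2C(N)=O)C1`, which differs from compound 1 by ethyl in place of cyclohexyl on a saturated chain carbon bound to an amine nitrogen in a ring. For the measured compounds named here, no pair of measured compounds shows this change, so the size of its step is unknown; a modest shift toward a higher number, or none beyond the scatter, is expected, as a 1.4-fold higher number from compound 1 to compound 3 (0.14 log units; within the scatter). Compound 3 is estimated at 2600 nM, with a range from 800 nM to 8500 nM.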

Compound 3, half-maximal effective concentration: 3500 nM
Estimate against measurement, compound 3: 1.3-fold (0.13 log units) below; the measured number falls inside the stated range.
By their numbers in this assay, from the lowest: compound 2; then compounds 1 and 3 (each within the scatter of the next).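

Ethyl in place of cyclohexyl gives a 1.9-fold higher number from compound 1 to compound 3 (0.27 log units; within the scatter) in this assay, the first reading of this change. On a saturated chain carbon bound to an amine nitrogen in a ring, the carbocycle can therefore be replaced by a small open chain without a shift beyond the scatter. No supporting data on this result are available.

Still open, going by these compounds, is whether a phenyl ring, a carboxylic acid or a primary amine in that place would move the number beyond the scatter. On these data alone, a longer chain remains equally open.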